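A few compounds are considered here, and "the series" means these few. Any claim that something is new, unique, unknown or untested is made for them only; others in the source may bear on it.

Measured so far in an ADME assay on MCF-10A cells (Homo sapiens) for inhibition, with a stated time of 48 h; a lower number here means a stronger inhibitor, a higher number a weaker inhibitor:
Compound 1 `Cc1cccc(-c2noc([C@@H]3CCCN3C(=O)Nc3ccc(Cl)cc3)n2)c1`: > 50000 nM, a limit
Compound 2 `O=C(Nc1ccc(Cl)cc1)N1CCC[C@H]1c1nc(-c2ccc(F)cc2)no1`: > 50000 nM, a limit

Compound 2 has only a limit, > 50000 nM. Compound 3 `O=C(Nc1ccc(Cl)cc1)N1CCC[C@H]1c1nc(-c2ccc(Br)cc2)no1` has bromo in place of fluoro on an aromatic carbon, para to a large group: bromo in place of fluoro on an aromatic carbon. Within the data shown here, the only measured step bearing on this is a step that the two limits leave unreadable from compound 1 to compound 2, which gives no size to carry over. Both values shown sit at one limit: the limit of > 50000 nM in this assay, at which 2 of the 2 values shown sit. In this assay, no step beyond the scatter is therefore expected, and a further limit is the likeliest report. The expected step is a number no higher from compound 2 to compound 3 (the limit leaves the size open). For compound 3 the estimated value is 50000 nM, with an expected range of 20000 nM to 100000 nM.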

Compound 3, half-maximal inhibitory concentration: > 50000 nM
Compound 3: only a limit was reported; the forecaster's own chance of this, stated with the estimate: 80%; the middle value sits exactly at the limit.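

No step among compound 1, compound 2 and compound 3 can be read in this assay, since each value is a limit: the limit of > 50000 nM in this assay, at which 3 of the 3 values shown sit.

The compounds shown leave open how far these three differ, and whether any change on the shared core gives a measurable half-maximal inhibitory concentration in this assay.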